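A few compounds are considered here, and "the series" means these few. Any claim that something is new, unique, unknown or untested is made for them only; others in the source may bear on it.

Measured compounds:
compound 1 `Cc1ccc(-c2cc(C)n(S(=O)(=O)Oc3ccccc3)n2)cc1`: 15.2%
compound 2 `Cc1ccc(-c2cc(C)n(S(=O)(=O)Oc3ccc(I)cc3)n2)cc1`: 27%

In a functional assay on the whole organism for inhibition, with Mus musculus as the target, with stated times of 3 days and 30 min, at a dose of 30 mg/kg by the oral route (on this read-out higher numbers stand for more inhibition at the one dose given (going by the name of the read-out) and lower numbers for less inhibition), compound 2 stands highest of the two numbers; its nearest neighbour is compound 1, and the step of a number 11.8 percentage points higher from compound 1 to compound 2 (beyond the scatter) lies beyond the scatter. Compound 3 `Cc1ccc(-c2cc(C)n(S(=O)(=O)Oc3ccccc3Cl)n2)cc1` differs from compound 2 by 2-chlorophenyl in place of 4-iodophenyl on an oxygen. Within the data shown here, the only measured step, a number 11.8 percentage points higher from compound 1 to compound 2 (beyond the scatter), concerns iodo in place of hydrogen and bears only loosely on this change, which swaps one halogenated phenyl for another. A small step is therefore expected, likely within or near the scatter, and the expected step is a number 7 percentage points lower from compound 2 to compound 3 (within the scatter). Compound 3 is expected to give 20%, between 8% and 34%.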

Compound 3, a percentage reported as inhibition, in the whole organism at one dose (the size of the read-out at that dose, not a potency): 27%
Estimate against measurement, compound 3: 7 percentage points below, within the range that was stated.
By their numbers in this assay, from the lowest: compound 1; then compounds 2 and 3 (each within the scatter of the next).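

In this assay, putting 2-chlorophenyl in place of 4-iodophenyl on the oxygen bound to the sulfonyl sulfur gives no change at the digits printed from compound 2 to compound 3 (within the scatter). Chloro in place of hydrogen gives a number 11.8 percentage points higher from compound 1 to compound 3 (beyond the scatter), so two different halogens at different places on the phenyl both set their compounds apart from compound 1. Nothing available explains why these two groups read alike. Since compounds 2 and 3 differ in both halogen and place, the compounds shown do not separate these two features. Going by these compounds, whether an amine or a carboxylic acid on this phenyl would read like a halogen also remains open.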